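The source may hold more compounds than are shown below. What is called first, only, known or untested is meant among the compounds shown, and "the series" means these compounds.

Compound 1 `CCn1c(C(=O)NCCCN(C)C)ccc1C(CC)(CC)c1ccc(OCC(O)C(C)(C)C)c(C)c1`: 360 nM
Compound 2 `CCn1c(C(=O)NCC(OC)OC)ccc1C(CC)(CC)c1ccc(OCC(O)C(C)(C)C)c(C)c1`: 23200 nM
Compound 3 `CCn1c(C(=O)NCCN)ccc1C(CC)(CC)c1ccc(OCC(O)C(C)(C)C)c(C)c1`: 176 nM

In a functional assay on HepG2 cells (Homo sapiens), read by MTT assay, with a stated time of 48 h (a lower number here means a stronger inhibitor, a higher number a weaker inhibitor), compound 3 gives the lowest number of the three, 176 nM. Its nearest neighbour is close, with a 2.0-fold lower number from compound 1 to compound 3 (0.31 log units; beyond the scatter), while the other lies far off, with a 130-fold lower number from compound 2 to compound 3 (2.12 log units; beyond the scatter).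

Compound 4 `CCn1c(C(=O)OCc2ccc(F)cc2)ccc1C(CC)(CC)c1ccc(OCC(O)C(C)(C)C)c(C)c1` carries (4-fluorobenzyl)oxy in place of (2-aminoethyl)amino on a carbonyl carbon. Going by the values given here, no measured step makes this exact change, so the evidence is indirect. The two compounds with an amino group in the side chain give far lower numbers than the one without, as the large steps of a 64-fold higher number from compound 1 to compound 2 (1.81 log units; beyond the scatter) and a 130-fold lower number from compound 2 to compound 3 (2.12 log units; beyond the scatter) show. Compound 4 also has no amino group, so a large step to a higher number is expected in this assay. Among the compounds with values here, its aromatic ring has no measured counterpart, which keeps the range wide.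

The estimated change is a 34-fold higher number from compound 3 to compound 4 (1.53 log units; beyond the scatter). For compound 4, the expected value is 6000 nM, with an estimated range of 1000 nM to 30000 nM.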

Compound 4, half-maximal inhibitory concentration: > 50000 nM
Compound 4 gave a limit, no number; the forecaster's own chance of this, stated with the estimate: 10%; middle value at least 8.3-fold (0.92 log units) away from the limit.
By their numbers in this assay, from the lowest: compound 3; then compound 1; then compound 2. At a limit, above all of these: compound 4.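

In this assay compound 4 gives only a limit, > 50000 nM, and not a number. Until now, every compound shown kept an amide-type nitrogen on this carbonyl carbon, and the new result shows that (4-fluorobenzyl)oxy there gives a much higher number than either amine-bearing chain, with an at least 280-fold higher number from compound 3 to compound 4 (2.45 log units; beyond the scatter) and an at least 130-fold higher number from compound 1 to compound 4 (2.14 log units; beyond the scatter). It also ends higher than the side chain without an amine, with an at least 2.1-fold higher number from compound 2 to compound 4 (0.33 log units; beyond the scatter), so the number can rise further even when the starting chain has no amine.

This single change replaces the linking nitrogen, the chain and the ring together, so the compounds shown cannot separate their contributions. Still open, as far as these compounds go, is how a (4-fluorobenzyl)amino group or a (2-aminoethyl)oxy group on this carbonyl carbon would read.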